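The source may report more compounds than this note shows. Statements on the series, on what has been measured and on what is new or still open speak of the compounds shown alone.

Compound 3 `Brc1ccc(-c2nnc(C(NCc3ccccc3)c3ccc[nH]3)o2)cc1` gives 96600 nM in a functional assay on MCF7 cells (Homo sapiens) for cytotoxicity, read by MTT assay, with a stated time of 24 h (on this read-out higher numbers stand for weaker inhibition and lower numbers for stronger inhibition), the highest of the three numbers recorded. Compound 1 `Clc1cccc(-c2nnc(C(NCc3ccccc3)c3ccc[nH]3)o2)c1` gives 56700 nM in this assay, and compound 2 `Clc1ccc(-c2nnc(C(NCc3ccccc3)c3ccc[nH]3)o2)cc1Cl` gives 13900 nM. Compound 4 `Cc1cccc(-c2nnc(C(NCc3ccccc3)c3ccc[nH]3)o2)c1` is not yet measured; it differs from compound 3 by 3-methylphenyl in place of 4-bromophenyl on an aromatic carbon. The step bearing on this change is a 1.7-fold higher number from compound 1 to compound 3 (0.23 log units; within the scatter), where a substituent in the same ring position left; that step lay within the scatter. The other step, a 6.9-fold higher number from compound 2 to compound 3 (0.84 log units; beyond the scatter), was beyond the scatter. Among the measured compounds shown here, no measured compound carries a methyl group, so the expected step is a 1.6-fold lower number from compound 3 to compound 4 (0.21 log units; within the scatter), a small lowering of the number, possibly within the scatter. Compound 4 is therefore estimated at 60000 nM, within a range from 20000 nM to 150000 nM.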

Compound 4, half-maximal inhibitory concentration: 480000 nM
Compound 4: middle estimate off by 8.0-fold (0.90 log units), on the low side; the measured number lies above the stated range.
By their numbers in this assay, from the lowest: compound 2; then compounds 1 and 3 (each within the scatter of the next); then compound 4.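

In this assay, among the compounds shown here, methyl in place of chloro is the first change on this aryl ring to show a clear loss at a single substituent, an 8.5-fold higher number from compound 1 to compound 4 (0.93 log units; beyond the scatter). The 3-methylphenyl group also separates from both other aryl groups, with a 5.0-fold higher number from compound 3 to compound 4 (0.70 log units; beyond the scatter) and, the largest step, a 35-fold higher number from compound 2 to compound 4 (1.54 log units; beyond the scatter), so all three halogen-bearing compounds give lower numbers than compound 4. Nothing measured here explains this separation.

From the compounds shown here alone, it remains open whether a methoxy group, an amine or a carboxylic acid on this ring would give numbers closer to compound 4 or to the halogen-bearing compounds. Going by these compounds, the 4-methylphenyl group also remains open.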